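The compounds below may be only part of what the source reports. "The series", "measured", "known", "first", "only" and "open" are said of these compounds alone.

Among the compounds with values here, in an assay on CHO cells for displacement of a labelled ligand from Alpha-1A adrenergic receptor (Homo sapiens) (a higher number here means a weaker inhibitor, a lower number a stronger inhibitor), compound 1 `COc1cccc(OC)c1OCCNCCOc1ccccc1OCc1ccc(Cl)cc1` gives 0.251 nM, and compound 2 `COc1cccc(OC)c1OCCNCCOc1ccccc1OCc1cccc(C)c1` gives 0.398 nM; the step of a 1.6-fold higher number from compound 1 to compound 2 (0.20 log units; within the scatter) lies within the scatter, so the two numbers cannot be told apart, and compound 2 stands level with the only other compound measured. Compound 3 `COc1cccc(OC)c1OCCNCCOc1ccccc1OCc1ccc([N+](=O)[O-])cc1` differs from compound 2 by 4-nitrophenyl in place of 3-methylphenyl on a saturated chain carbon bound to an oxygen on an aromatic ring. Within the data shown here, the one step bearing on this place, a 1.6-fold higher number from compound 1 to compound 2 (0.20 log units; within the scatter), moved nothing beyond the scatter, and no nitro group has been measured yet. The expected step for compound 3 in this assay is therefore a 1.0-fold higher number from compound 2 to compound 3 (0.00 log units; within the scatter). Compound 3 is estimated at 0.4 nM, within 0.15 nM to 1.2 nM.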

Compound 3, inhibition constant: 1.26 nM
Compound 3: middle estimate off by 3.2-fold (0.50 log units), on the low side, outside the stated range (above it).
By their numbers in this assay, from the lowest: compounds 1 and 2 (each within the scatter of the next); then compound 3.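

The position is not indifferent to every change: in this assay, 4-nitrophenyl in place of 3-methylphenyl gives a 3.2-fold higher number from compound 2 to compound 3 (0.50 log units; beyond the scatter). Within the data shown here, the single swap of nitro for chloro on an aromatic carbon gives a 5.0-fold higher number from compound 1 to compound 3 (0.70 log units; beyond the scatter), making compound 3 the weakest of the three, though both steps are modest. Nothing shown gives a reason for this shift. From the compounds shown here alone, whether 3-nitrophenyl would behave like 4-nitrophenyl stays open, and so does how an amine or a carboxylic acid on that ring would compare.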